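A Side-Chain Swap Starting from an Assay Limit

The compounds below may be only part of what the source reports. "The series", "measured", "known", "first", "only" and "open" are said of these compounds alone.

Three related compounds have gone through an ADME assay on HeLa cells (Homo sapiens) for inhibition, read by MTT assay, with a stated time of 48 h (a higher number here means a weaker inhibitor, a lower number a stronger inhibitor), so far, and the record is thin. Compound 1 (`CCOC(=O)C(=O)CC(=O)/C=C/c1cn(Cc2ccc(Cl)cc2)c2ccccc12`) has the entry "not determined" (no result reported) there and compound 2 (`CCOC(=O)C(=O)CC(=O)/C=C/c1cn(Cc2ccc(C#N)cc2)c2ccccc12`) has the entry "not determined" (no result reported) there, so neither offers a number. Compound 3 (`O=C(/C=C/c1cn(Cc2ccc(Cl)cc2)c2ccccc12)CC(=O)C(=O)O`) stands at > 40000 nM as its only result, and this is a limit of the assay and not a number.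

The next compound, compound 4 (`O=C(/C=C/c1cn(CC(=O)N2CCOCC2)c2ccccc12)CC(=O)C(=O)O`), keeps the shared core and carries (morpholin-4-yl)carbonyl in place of 4-chlorophenyl on a saturated chain carbon bound to an aromatic nitrogen, and the full count of that change is (morpholin-4-yl)carbonyl in place of 4-chlorophenyl on a saturated chain carbon bound to an aromatic nitrogen for comparison. For the measured compounds named here, no pair of measured compounds shows what such a swap does, so no step beyond the usual scatter is expected, in either direction. The estimated step is a step that the limit leaves unreadable from compound 3 to compound 4 and it stays small. Another limit is the likeliest report. For compound 4 the estimated value is 45000 nM with 20000 nM to 80000 nM as the expected range.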

Compound 4, half-maximal inhibitory concentration: > 40000 nM
Compound 4 was reported as a limit; the forecaster's own chance of this, stated with the estimate: 85%; the middle value lies beyond the limit too.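

Compound 3 and compound 4 are each reported only as a limit of the assay and not as a number, so no step can be read between them: the limit of > 40000 nM in this assay, at which 2 of the 4 values shown sit.

The compounds shown leave open what (morpholin-4-yl)carbonyl in place of 4-chlorophenyl does in this assay.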